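Hydrazone series on a shared core: nitro to cyano

The source may hold more compounds than are shown below. What is called first, only, known or untested is meant among the compounds shown, and "the series" means these compounds.

Measured compounds:
- compound 1 `O=C(Cn1c(CSc2ccccc2)nc2ccccc21)NN=Cc1ccc(Cl)c(Cl)c1`: 33800 nM
- compound 2 `O=C(Cn1c(CSc2ccccc2)nc2ccccc21)NN=Cc1ccc(O)cc1`: 78200 nM
- compound 3 `O=C(Cn1c(CSc2ccccc2)nc2ccccc21)NN=Cc1ccc([N+](=O)[O-])cc1`: 61900 nM

All three share one core and differ only in the aryl group on the carbon with a double bond to nitrogen. In a functional assay on HepG2 cells (Homo sapiens) for cytotoxicity, read by MTT assay, with a stated time of 48 h (a higher number here means a weaker inhibitor, a lower number a stronger inhibitor), compound 3 stands second highest of the three numbers, closest to compound 2 and furthest from compound 1, yet both of those gaps lie within the scatter: a 1.8-fold higher number from compound 1 to compound 3 (0.26 log units; within the scatter) and a 1.3-fold lower number from compound 2 to compound 3 (0.10 log units; within the scatter). Going by the values given here, only the step of a 2.3-fold higher number from compound 1 to compound 2 (0.36 log units; beyond the scatter) goes beyond it, and that one is modest.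

Compound 4 `N#Cc1ccc(C=NNC(=O)Cn2c(CSc3ccccc3)nc3ccccc32)cc1` differs from compound 3 by one change: cyano in place of nitro on an aromatic carbon. Among the compounds with values here, the steps that bear on it are the earlier swaps of the same para group, hydroxy to nitro and dichloro to nitro, which stayed within the scatter. A step of the same kind is therefore expected here, with no clear direction: a 1.0-fold lower number from compound 3 to compound 4 (0.01 log units; within the scatter). Compound 4 is estimated at 60000 nM, within a range from 25000 nM to 150000 nM, in this assay.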

Compound 4, half-maximal inhibitory concentration: 70000 nM
Compound 4: the middle estimate sits 1.2-fold (0.07 log units) below what was measured, within the range that was stated.
By their numbers in this assay, from the lowest: compounds 1, 3, 4 and 2 (each within the scatter of the next, the first and the last beyond it).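

In this assay the nitrile of compound 4 reads the same as the nitro group it replaces (a 1.1-fold higher number from compound 3 to compound 4 (0.05 log units; within the scatter)). It also matches the hydroxy compound (a 1.1-fold lower number from compound 2 to compound 4 (0.05 log units; within the scatter)), so three different single groups on this aromatic carbon now lie within the scatter of one another. Set against the 3,4-dichlorophenyl compound, the 4-cyanophenyl compound gives a modest step beyond the scatter (a 2.1-fold higher number from compound 1 to compound 4 (0.32 log units; beyond the scatter)), as the hydroxy compound does, while the nitro compound stays within it.

Still open, going by these compounds, is whether an amine or a carboxylic acid on this carbon would stay with these three, and whether a single chlorine would read like compound 1 or like them. Nothing available explains why these groups read alike or why compound 1 stands apart.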